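The source may report more compounds than this note shows. Statements on the series, on what has been measured and on what is new or still open speak of the compounds shown alone.

Compound 1 `O=S(=O)(Nc1ccc(-c2nc3ccccc3o2)cc1)c1ccccc1O` is the starting point of this account. In an assay on isolated protein for inhibition of malate dehydrogenase, mitochondrial (Sus scrofa), with stated times of 45 min and 30 min (on this read-out higher numbers stand for weaker inhibition and lower numbers for stronger inhibition), compound 1 gives > 63000 nM, which is a limit of the assay and not a number. Two related compounds built on the shared core were also tested. Compound 2 `O=S(=O)(Nc1ccc2oc(-c3ccccc3)nc2c1)c1ccccc1Cl` gives in this assay > 63000 nM, again a limit rather than a number. Compound 3 `COc1cccc(S(=O)(=O)Nc2ccc3oc(-c4ccccc4)nc3c2)c1` gives in this assay > 63000 nM, once more a limit. Within the data shown here, the only single change between measured compounds, a step that the two limits leave unreadable from compound 2 to compound 3, is thus unreadable, and every value shown rests at the limit of > 63000 nM in this assay, at which 3 of the 3 values shown sit, so compound 1 stands level with the others at that limit.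

Compound 4 `COc1ccccc1S(=O)(=O)Nc1ccc(-c2nc3ccccc3o2)cc1` differs from compound 1 by methyl in place of hydrogen on an oxygen on an aromatic ring. Among the measured compounds shown here, no measured step bears on this change: the one step available cannot be read, and none of the measured compounds carries the methoxy at this place on the ring bearing the sulfonyl sulfur. There is therefore no basis for expecting a step in this assay beyond the scatter in either direction. Compound 4 is expected to sit at 100000 nM, in a range from 30000 nM to 400000 nM. The expected step from compound 1 is a step that the limit leaves unreadable from compound 1 to compound 4.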

Compound 4, half-maximal inhibitory concentration: > 63000 nM
Compound 4 ended at the assay's limit (the forecaster's own chance of this, stated with the estimate: 85%); the middle value does not contradict the limit.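

Compound 1 and compound 4 both give only a limit in this assay, so no step between them can be read, and all the compounds shown stay together: the limit of > 63000 nM in this assay, at which 4 of the 4 values shown sit. The compounds shown leave open how hydroxy and methoxy compare here, and whether any compound on the shared core gives a number rather than a limit in this assay.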